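Chloroaryl ketone branch replacing naphthyloxy in piperazine amide series

This account rests on a few compounds, and the source may have more. Where it says the series, first, only, none or still open, it means among the compounds named here.

Measured so far in an assay on HEK293 cells for displacement of a labelled ligand from Melanocortin receptor 4 (Homo sapiens); a lower number here means a stronger inhibitor, a higher number a weaker inhibitor:
compound 1, `CC(C)C[C@H](N)c1cc(C(F)(F)F)ccc1N1CCN(C(=O)CSc2ccc(Cl)cc2Cl)CC1`, gives 1500 nM
compound 2, `Cc1cc(CC(C)C(=O)N2CCN(c3ccc(C(F)(F)F)cc3[C@@H](N)CC(C)C)CC2)ccc1Cl`, gives 71 nM
compound 3, `CC(C)C[C@H](N)c1cc(C(F)(F)F)ccc1N1CCN(C(=O)COc2ccc3ccccc3c2)CC1`, gives 2000 nM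

Compound 3 carries the highest number of the three in this assay; compound 1 sits within the scatter of it, while compound 2 sits far below it, with a 28-fold higher number from compound 2 to compound 3 (1.45 log units; beyond the scatter).

Compound 4, `CC(C)C[C@H](N)c1cc(C(F)(F)F)ccc1N1CCN(C(=O)CC(C)C(=O)c2ccc(Cl)cc2)CC1`, differs from compound 3 at one place: 1-((4-chlorophenyl)carbonyl)ethyl in place of (naphthalen-2-yl)oxy on a saturated chain carbon bound to a carbonyl carbon. The entering group resembles the branch in compound 2 in its chain length, its methyl branch and its chlorine-bearing ring, but puts a carbonyl where compound 2 has a saturated carbon. For the measured compounds named here, two measured steps bear on this kind of change, and both are large: a 21-fold lower number from compound 1 to compound 2 (1.32 log units; beyond the scatter) and a 28-fold higher number from compound 2 to compound 3 (1.45 log units; beyond the scatter). A step of that direction, somewhat smaller than the full return to compound 2, is expected in this assay, namely a 13-fold lower number from compound 3 to compound 4 (1.12 log units; beyond the scatter). Compound 4 is therefore estimated at 150 nM, within a range of 40 nM to 600 nM.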

Compound 4, inhibition constant: 1100 nM
Beside the measured number, compound 4's estimate is 7.3-fold (0.87 log units) below it; measured number outside the range, above it.
By their numbers in this assay, from the lowest: compound 2; then compounds 4, 1 and 3 (each within the scatter of the next).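

In this assay, the 1-((4-chlorophenyl)carbonyl)ethyl group leaves compound 4 level with the earlier weak compounds, with a 1.8-fold lower number from compound 3 to compound 4 (0.26 log units; within the scatter) and a 1.4-fold lower number from compound 1 to compound 4 (0.13 log units; within the scatter), so replacing (naphthalen-2-yl)oxy or (2,4-dichlorophenyl)sulfanyl with this group changes nothing that can be read. A chlorine-bearing ring and a methyl branch are thus not enough on their own to match compound 2, which remains apart, with a 15-fold higher number from compound 2 to compound 4 (1.19 log units; beyond the scatter). No measurement shown explains this result.

The groups in compound 2 and compound 4 differ in both the carbonyl and the ring methyl, so the compounds shown leave open which difference accounts for the gap. A hydroxyl in place of the carbonyl of compound 4, or a methyl added to its chlorophenyl ring, would begin to separate the two.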